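Adding a Third Methoxy Group to Compound 2

The source may report more compounds than this note shows. Statements on the series, on what has been measured and on what is new or still open speak of the compounds shown alone.

Compound 1, `CCOC(=O)[C@H](CCC(=O)O)NC(=O)c1ccc(CNc2nc3cc(N)cc(N)c3nc2-c2ccccc2)cc1`: < 100000 nM. Compound 2, `COc1ccc(CNc2nc3cc(N)cc(N)c3nc2-c2ccccc2)cc1OC`: 1860 nM.

In a functional assay on HT-29 cells (Homo sapiens) for inhibition, read by sulforhodamine B assay, with a stated time of 48 h (a lower number here means a stronger inhibitor of growth, a higher number a weaker inhibitor of growth), compound 1 gives only a limit, < 100000 nM. Within the data shown here, compound 2 gives the only number, 1860 nM, and so stands alone among the measured values. Compound 3, `COc1cc(CNc2nc3cc(N)cc(N)c3nc2-c2ccccc2)cc(OC)c1OC`, differs from compound 2 by methoxy in place of hydrogen on an aromatic carbon. Among the measured compounds shown here, no step between measured compounds is available, so the size of this change cannot be read from the data; a shift no larger than the usual scatter, in either direction, is expected. Compound 3 is therefore estimated at 1500 nM, between 400 nM and 6000 nM, a step of a 1.2-fold lower number from compound 2 to compound 3 (0.09 log units; within the scatter) expected to stay within the scatter.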

Compound 3, concentration for 50% growth inhibition: 8710 nM
For compound 3 the middle estimate is 5.8-fold (0.76 log units) below the measured one; the whole stated range lies below it.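

In this assay, methoxy in place of hydrogen on this aromatic carbon, ortho to a methoxy group, gives a 4.7-fold higher number from compound 2 to compound 3 (0.67 log units; beyond the scatter) and so weakens growth inhibition. Among these compounds, this is the first step measured at this position, and it shows that the position responds to this change rather than leaving the value within the scatter. Nothing given here accounts for the step. As far as these compounds go, whether fluorine or a hydroxyl group on the same carbon would bring a similar step stays open, as does whether the step depends on the neighbouring methoxy groups already present.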